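The source may hold more compounds than are shown below. What is called first, only, known or untested is meant among the compounds shown, and "the series" means these compounds.

Measured so far in an ADME assay on microsomes from liver (Homo sapiens) for metabolic stability, read by LC-MS, tested at 0.5 uM; on this read-out higher numbers stand for a longer-lived compound and lower numbers for a shorter-lived compound:
- compound 1 `Cc1cc(CCOc2ccc(-c3c(C)nc(C)c([C@H](OC(C)(C)C)C(=O)O)c3N3CCC(C)(C)CC3)cc2)ccc1F`: a limit, > 2 h
- compound 2 `Cc1nc(C)c([C@H](OC(C)(C)C)C(=O)O)c(N2CCC(C)(C)CC2)c1-c1ccc(CCCc2ccc(F)cc2)cc1`: a limit, > 2 h

Compound 2 sits at the limit of this assay, as does compound 1; both values are limits, not numbers, and the limit of > 2 h in this assay, at which 2 of the 2 values shown sit, describes this. Going by the values given here, the only measured step, a step that the two limits leave unreadable from compound 1 to compound 2, is therefore of unreadable size.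

Compound 3 `Cc1ncsc1CCOc1ccc(-c2c(C)nc(C)c([C@H](OC(C)(C)C)C(=O)O)c2N2CCC(C)(C)CC2)cc1` differs from compound 2 as follows: 2-(4-methyl-1,3-thiazol-5-yl)ethoxy in place of 3-(4-fluorophenyl)propyl on an aromatic carbon. Among the compounds with values here, no measured step covers a thiazole ethoxy group, so the expectation rests only on the two limits.

Compound 3 is expected to remain near the limit, estimated at 2.5 h (range 0.9 h to 6 h). The expected step that the limit leaves unreadable from compound 2 to compound 3 is thus no change beyond the scatter.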

Compound 3, half-life: 1.5 h
Compound 3: the middle estimate sits 1.7-fold (0.22 log units) above what was measured, and the stated range covers the measured number.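

In this assay, going by these compounds alone, the 2-(4-methyl-1,3-thiazol-5-yl)ethoxy group gives the first number at this position that is not a limit. The change reads as an at least 1.3-fold lower number from compound 2 to compound 3 (0.12 log units; that floor lies within the scatter), and the swap of the terminal ring on the ethoxy chain reads as an at least 1.3-fold lower number from compound 1 to compound 3 (0.12 log units; that floor lies within the scatter). Both steps are floors only, so neither establishes a real loss of half-life, and their true size stays hidden: the limit of > 2 h in this assay, at which 2 of the 3 values shown sit.

Open, from the compounds shown here alone, is whether a pyridine or a morpholine on the same ethoxy chain would give a readable number in this assay. Also open, going by these compounds, is whether the thiazole methyl contributes to the value of compound 3.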